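Swapping the benzamide aryl: from compound 3 to compound 4

The compounds below may be only part of what the source reports. "The series", "measured", "known", "first", "only" and "open" are said of these compounds alone.

In an assay on isolated protein for inhibition of Rho-associated protein kinase 1 (Homo sapiens), read by scintillation counting, radiometric assay and 33P incorporation, with a stated time of 40 min, in the presence of a further agent that is not named here (a lower number here means a stronger inhibitor, a higher number a weaker inhibitor), three compounds have been measured:

compound 1, `CC(=O)c1ccc(OCC(=O)Nc2cccc(NC(=O)c3ccc(N(C)C)cc3)c2)cc1F`, gives 445 nM
compound 2, `CN(C)c1ccc(C(=O)Nc2cccc(NC(=O)COc3ccc4c(c3)OCCO4)c2)cc1`, is reported only as a limit, > 10000 nM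
compound 3, `O=C(COc1ccc2c(=O)ccoc2c1)Nc1cccc(NC(=O)c2ccc(F)cc2)c1`, gives 129 nM

Compound 3 stands lowest of the two numbers; compound 1 sits higher by a gap that lies beyond the usual scatter, and compound 2 contributes only a limit (the limit of > 10000 nM in this assay, at which 1 of the 3 values shown sits). Compound 4, `O=C(COc1ccc2c(=O)ccoc2c1)Nc1cccc(NC(=O)c2cccc([N+](=O)[O-])c2)c1`, has not yet been measured. It differs from compound 3 in one place: 3-nitrophenyl in place of 4-fluorophenyl on a carbonyl carbon. Among the measured compounds shown here, the single measured step, an at least 22-fold higher number from compound 1 to compound 2 (1.35 log units; beyond the scatter), concerns the group on the oxygen on the saturated carbon, a different place from the carbonyl carbon changed here, so no measured step bears directly on this change. With nothing to point in either direction, the step from compound 3 to compound 4 is expected to stay within the usual scatter, a 1.2-fold higher number from compound 3 to compound 4 (0.09 log units; within the scatter). Compound 4 is therefore estimated at 160 nM, with a range from 50 nM to 600 nM.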

Compound 4, half-maximal inhibitory concentration: 528 nM
The estimate for compound 4 lay 3.3-fold (0.52 log units) below the measured number; the range from low to high includes it.
By their numbers in this assay, from the lowest: compound 3; then compounds 1 and 4 (each within the scatter of the next). At a limit, above all of these: compound 2.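

In this assay, 3-nitrophenyl in place of 4-fluorophenyl on a carbonyl carbon gives a 4.1-fold higher number from compound 3 to compound 4 (0.61 log units; beyond the scatter), a modest step. Among the compounds shown here, this is the first measured change at this place, and it shows that the number responds to the aryl group held there while the rest of compound 3 stays fixed. Of the two groups, 4-fluorophenyl gives the lower number, but nothing measured here accounts for the difference.

The swap alters both the group on the ring and where it is printed in the name, so the compounds shown do not separate these two changes. From the compounds shown here alone, it also remains open how an amine or a carboxylic acid on that ring would compare with compound 3 on the same core.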